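Series notes: sulfonamide core, aryl change on the thiophene

This account rests on a few compounds, and the source may have more. Where it says the series, first, only, none or still open, it means among the compounds named here.

Compound 1 `COc1cc2c(cc1N1C[C@@H](C)N[C@@H](C)C1)N(S(=O)(=O)CCc1ccccc1Cl)CC2` and compound 2 `COc1cc2c(cc1N1C[C@@H](C)N[C@@H](C)C1)N(S(=O)(=O)c1ccc(-c3ccccn3)s1)CC2` share one core. In a functional assay with growth hormone secretagogue receptor type 1 (Homo sapiens) as the target (a lower number here means a smaller maximal response, a higher number a larger maximal response), compound 1 gives 0.9, and in this assay compound 2 gives 0.9; the step of no change at the digits printed from compound 1 to compound 2 (within the scatter) lies within the scatter, so compound 2 stands level with compound 1. Compound 3 `COc1cc2c(cc1N1C[C@@H](C)N[C@@H](C)C1)N(S(=O)(=O)c1ccc(-c3ccon3)s1)CC2` differs from compound 2 in one place: 1,2-oxazol-3-yl in place of pyridin-2-yl on an aromatic carbon. Going by the values given here, no measured step bears on this exact change; the one step known, no change at the digits printed from compound 1 to compound 2 (within the scatter), was a larger alteration and moved nothing. Compound 3 is therefore expected to hold the same level, no change at the digits printed from compound 2 to compound 3 (within the scatter), with an estimated 0.9 and a range from 0.7 to 1.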

Compound 3, intrinsic activity: the largest response reached, as a fraction of the reference agonist's: 0.9
Beside the measured number, compound 3's estimate shows no gap at the digits printed, and the stated range covers the measured number.
By their numbers in this assay, from the lowest: compounds 1, 2 and 3 (each within the scatter of the next).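

At this position, on an aromatic carbon next to the ring sulfur, a five-membered aromatic ring with 2 hetero atoms takes the place of a six-membered aromatic ring with 1 hetero atom, and this assay reads no change at the digits printed from compound 2 to compound 3 (within the scatter). Measured against the 2-(2-chlorophenyl)ethyl group on the sulfonyl sulfur, 5-(1,2-oxazol-3-yl)thiophen-2-yl likewise gives no change at the digits printed from compound 1 to compound 3 (within the scatter). No available data explain this result.

From the compounds shown here alone, whether a carboxylic acid or a primary amine at this place would keep the response level remains open. No group shown separates from the others in this assay, so what would lower the maximal response is unknown.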